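A few compounds are considered here, and "the series" means these few. Any claim that something is new, unique, unknown or untested is made for them only; others in the source may bear on it.

Measured compounds in a functional assay on A549 cells (Homo sapiens) for antiproliferative activity, read by XTT assay, with a stated time of 72 h; on this read-out lower numbers stand for stronger inhibition and higher numbers for weaker inhibition:

Compound 1 `COc1ccc(-c2cc3ccccc3nc2C=O)cc1`: > 10000 nM
Compound 2 `COc1ccc(-c2cc3ccccc3nc2/C=C/C(=O)c2ccc(F)cc2)cc1`: 8320 nM
Compound 3 `COc1ccc(-c2cc3ccccc3nc2/C=C/C(=O)c2ccc(N)cc2)cc1`: 7530 nM

Compound 1 stands apart from the other two: in this assay compound 1 gives only a limit, > 10000 nM, and no number is known for it. This is the limit of > 10000 nM in this assay, at which 1 of the 3 values shown sits. Compound 2 and compound 3 both carry an extended side chain ending in an aryl ketone, and their values sit close together. Among the compounds with values here, the only measured step between them, a 1.1-fold lower number from compound 2 to compound 3 (0.04 log units; within the scatter), shows that swapping the substituent on that aryl ring left the read-out essentially unchanged.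

Compound 4 `COc1ccc(-c2cc3ccccc3nc2/C=C/C(=O)c2ccsc2)cc1` has not yet been measured. It differs from compound 1 by 2-((thiophen-3-yl)carbonyl)ethenyl in place of formyl on an aromatic carbon. Within the data shown here, no measured step starts from compound 1, so the expectation rests on what compound 2 and compound 3 show: a closely related extension at the same position gives a measurable number rather than a limit, and the identity of the terminal aryl group matters little. Compound 4 is therefore expected to land in the same region, and the estimated step of an at least 1.3-fold lower number from compound 1 to compound 4 (0.12 log units; that floor lies within the scatter) reflects a move from a limit to a measured value. The estimate for compound 4 is 7500 nM, with a range from 3000 nM to 20000 nM.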

Compound 4, half-maximal inhibitory concentration: 8210 nM
For compound 4 the middle estimate is 1.1-fold (0.04 log units) below the measured one; the measured number falls inside the stated range.
By their numbers in this assay, from the lowest: compounds 3, 4 and 2 (each within the scatter of the next). At a limit, above all of these: compound 1.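

In this assay, the earlier pair had changed only a substituent on a phenyl ring, whereas here the ring on the carbonyl carbon itself gives way to a five-membered aromatic ring with 1 hetero atom, and the number stays put in both comparisons: a 1.1-fold higher number from compound 3 to compound 4 (0.04 log units; within the scatter) and a 1.0-fold lower number from compound 2 to compound 4 (0.01 log units; within the scatter). Across these three compounds, then, thiophen-3-yl, 4-fluorophenyl and 4-aminophenyl on the carbonyl carbon cannot be told apart in this read-out. The comparison with the formyl compound gives only a floor, an at least 1.2-fold lower number from compound 1 to compound 4 (0.08 log units; that floor lies within the scatter), so it does not establish a real gain from the 2-((thiophen-3-yl)carbonyl)ethenyl group, and the value of compound 1 remains a limit and not a number: the limit of > 10000 nM in this assay, at which 1 of the 4 values shown sits.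

From the compounds shown here alone, what remains open is whether a carboxylic acid or an aliphatic amine in place of the aromatic ring on the carbonyl carbon would move the number beyond the scatter. Also open, going by these compounds, is how the read-out would respond if the ethenyl link gave way to a longer chain or a saturated two-carbon link, leaving the rest of the compound unchanged.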